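Butyl for isopropyl on a weak spinach inhibitor

The source may hold more compounds than are shown below. What is called first, only, known or untested is meant among the compounds shown, and "the series" means these compounds.

Of the compounds shown here, two have been measured so far. Compound 1 `CC(C)(C)c1ncc(C(=O)Nc2cc(O)cc(Cl)c2)nc1Cl` gives in a functional assay on the whole organism for inhibition, with Spinacia oleracea as the target, read by spectrophotometry, with a stated time of 4 h (a lower number here means a stronger inhibitor, a higher number a weaker inhibitor), a value of 105000 nM, and compound 2 `CC(C)c1cnc(C(=O)/C=C/c2ccccc2O)cn1` gives 167000 nM in this assay. These two numbers lie within the usual scatter of each other, so compound 2 cannot be set apart from compound 1 on this count. Compound 3 `CCCCc1cnc(C(=O)/C=C/c2ccccc2O)cn1` differs from compound 2 by butyl in place of isopropyl on an aromatic carbon. Among the measured compounds shown here, no measured pair shows such an exchange, so nothing is known about its size; the expectation is a step in this assay no larger than the scatter, in either direction. For compound 3 the expected value is 150000 nM, with a range from 60000 nM to 400000 nM, which means an expected step of a 1.1-fold lower number from compound 2 to compound 3 (0.05 log units; within the scatter).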

Compound 3, half-maximal inhibitory concentration: 184000 nM
Compound 3: middle estimate off by 1.2-fold (0.09 log units), on the low side; the range from low to high includes it.
By their numbers in this assay, from the lowest: compounds 1, 2 and 3 (each within the scatter of the next).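

Butyl in place of isopropyl on this aromatic carbon gives a 1.1-fold higher number from compound 2 to compound 3 (0.04 log units; within the scatter) in this assay, so the first exchange measured at this position produces no step beyond the scatter. This position therefore carries either of these two chains with no readable difference in inhibition. Nothing measured here bears on why the step is so small.

The compounds shown leave open whether an amine, a carboxylic acid or a hexyl chain at this position would move the number beyond the scatter. They also leave open whether the same exchange would behave alike on the core of compound 1.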